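The source may report more compounds than this note shows. Statements on the series, on what has been measured and on what is new or still open speak of the compounds shown alone.

Measured in an assay on Sf9 cells for inhibition of mitogen-activated protein kinase kinase kinase 14 variant S549D (Homo sapiens), with a stated time of 30 min, in the presence of a further agent that is not named here; a higher number here means a weaker inhibitor, a lower number a stronger inhibitor:
Compound 1, `C=CC(=O)NCC#Cc1ccc2ncn(-c3ccnc(N)n3)c2c1`, gives 6310 nM.
Compound 2, `C=Cc1cc(C#Cc2ccc3ncn(-c4ccnc(N)n4)c3c2)ccn1`, gives 20000 nM.
Compound 3, `C=Cc1ccnc(C#Cc2ccc3ncn(-c4ccnc(N)n4)c3c2)n1`, gives 1580 nM.

Compound 3 stands lowest of the three: a 4.0-fold lower number from compound 1 to compound 3 (0.60 log units; beyond the scatter) and a 13-fold lower number from compound 2 to compound 3 (1.10 log units; beyond the scatter), both beyond the scatter, while a 3.2-fold higher number from compound 1 to compound 2 (0.50 log units; beyond the scatter) runs the other way. Compound 4, `C=Cc1nccc(C#Cc2ccc3ncn(-c4ccnc(N)n4)c3c2)n1`, holds the same atoms as compound 3, joined differently: a group of 8 heavy atoms (6 carbon, 2 nitrogen; one six-membered aromatic ring with 2 hetero atoms) in place of a group of 8 heavy atoms (6 carbon, 2 nitrogen; one six-membered aromatic ring with 2 hetero atoms), on a triple-bonded carbon. Among the compounds with values here, no measured step rearranges a group within one ring; the steps into compound 3 exchange one ring type for another and are modest to large. With nothing that bears directly on this change, a step within the scatter, a 1.3-fold higher number from compound 3 to compound 4 (0.10 log units; within the scatter), is expected in this assay. Compound 4 is estimated at 2000 nM, range 700 nM to 6000 nM.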

Compound 4, half-maximal inhibitory concentration: 39800 nM
Compound 4: middle estimate off by 20-fold (1.30 log units), on the low side, and the stated range ends below it.
By their numbers in this assay, from the lowest: compound 3; then compound 1; then compounds 2 and 4 (each within the scatter of the next).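

Within one ring type, rearranging the same atoms on the triple-bonded carbon is enough to move the number in this assay (a 25-fold higher number from compound 3 to compound 4 (1.40 log units; beyond the scatter)), so ring type alone does not set it. The advantage of compound 3 over the ((vinylcarbonyl)amino)methyl compound is not shared by its isomer (a 6.3-fold higher number from compound 1 to compound 4 (0.80 log units; beyond the scatter)). Compound 4 also stays level with the 2-vinylpyridin-4-yl compound (a 2.0-fold higher number from compound 2 to compound 4 (0.30 log units; within the scatter)). No measurement shown explains the effect of the rearrangement. Going by these compounds, whether an ethyl group or an amine in place of the vinyl group on the ring of compound 3 would keep its number remains open.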